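The source may hold more compounds than are shown below. What is called first, only, known or untested is meant among the compounds shown, and "the series" means these compounds.

Measured so far in an assay on striatum for inhibition of sodium-dependent dopamine transporter (Rattus norvegicus); a lower number here means a stronger inhibitor, a higher number a weaker inhibitor:

compound 1 `COc1cc(CN[C@@H]2CO[C@H](C(c3ccccc3)c3ccccc3)C[C@H]2O)ccc1O` — 167 nM
compound 2 `COc1cc(O)cc(CN[C@@H]2CO[C@H](C(c3ccccc3)c3ccccc3)C[C@H]2O)c1` — 209 nM
compound 3 `Oc1ccc(CN[C@@H]2CO[C@H](C(c3ccc(F)cc3)c3ccc(F)cc3)C[C@H]2O)cc1F` — 13.1 nM

Compound 2 gives the highest of the three numbers in this assay. Its nearest neighbour is compound 1, and the step of a 1.3-fold higher number from compound 1 to compound 2 (0.10 log units; within the scatter) lies within the scatter, so the two read as equivalent. Compound 3 stands much lower, but it differs from compound 2 in more than one place, so only the two values themselves can be compared.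

Compound 4 `O[C@@H]1C[C@@H](C(c2ccccc2)c2ccccc2)OC[C@H]1NCc1ccc2occc2c1` is not yet measured in this assay. It differs from compound 2 as follows: 1-benzofuran-5-yl in place of 3-hydroxy-5-methoxyphenyl on a saturated chain carbon bound to an amine nitrogen.

Going by the values given here, only one step among the measured compounds touches the same position, the step from compound 1 to compound 2, and it was within the scatter; it exchanges one hydroxy-methoxyphenyl for another and says nothing about removing the hydrogen-bond donor or introducing the fused five-membered ring. The expectation for compound 4 in this assay therefore rests on little: a step of a 1.6-fold lower number from compound 2 to compound 4 (0.21 log units; within the scatter) is expected, small and uncertain in direction, with a wide range. Compound 4 is estimated at 130 nM, between 40 nM and 450 nM.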

Compound 4, inhibition constant: 234 nM
Estimate against measurement, compound 4: 1.8-fold (0.26 log units) below; the range from low to high includes it.
By their numbers in this assay, from the lowest: compound 3; then compounds 1, 2 and 4 (each within the scatter of the next).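

In this assay, the step of a 1.1-fold higher number from compound 2 to compound 4 (0.05 log units; within the scatter) and the step of a 1.4-fold higher number from compound 1 to compound 4 (0.15 log units; within the scatter) both stay within the scatter, so 1-benzofuran-5-yl reads as equivalent to either hydroxy-methoxyphenyl group at this position. Unlike the earlier swap between two hydroxy-methoxyphenyl groups, this change removes the hydrogen-bond donor counted on the leaving group and adds a five-membered aromatic ring, and neither alteration separates the values among compounds 1, 2 and 4. No measurement is available that explains this flat result.

Going by these compounds, whether an unsubstituted phenyl or an indol-5-yl group on the same carbon would also fall within this range remains open. Compound 3 differs from these compounds in more than one place, so its value cannot be assigned to any single change.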